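Swapping a Carboxy Group for Aminomethyl on a Hydrazone

The source may report more compounds than this note shows. Statements on the series, on what has been measured and on what is new or still open speak of the compounds shown alone.

Three close relatives of one shared core have been examined so far. Compound 1 `CC(C)(C)c1cc2c(N/N=C/c3ccc(O)cc3)ncnc2s1` carries a hydroxy group on its outer aromatic ring; in a functional assay on HCT-116 cells (Homo sapiens) for cytotoxicity, read by MTT assay, with a stated time of 3 days (a lower number here means a stronger inhibitor, a higher number a weaker inhibitor), compound 1 gives 0.844 ug/mL. Compound 2 `COC(=O)c1ccc(/C=N/Nc2ncnc3sc(C(C)(C)C)cc23)cc1` carries a methyl ester in the same position, and in this assay compound 2 gives "not determined" (no result reported). Compound 3 `CC(C)(C)c1cc2c(N/N=C/c3ccc(C(=O)O)cc3)ncnc2s1` carries a carboxy group, and in this assay compound 3 gives 9.99 ug/mL, the highest number among the two that were reported. Going by the values given here, the only single-place step measured so far, a 12-fold higher number from compound 1 to compound 3 (1.07 log units; beyond the scatter), shows that exchanging hydroxy for carboxy weakens the compound considerably.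

Compound 4 `CC(C)(C)c1cc2c(N/N=C/c3ccc(CN)cc3)ncnc2s1` differs from compound 3 in one place: aminomethyl in place of carboxy on an aromatic carbon. Among the compounds with values here, nothing measured bears directly on aminomethyl; the one known step says only that the carboxy group sits at the weak end. A return toward the hydroxy compound is therefore expected but not assured, so compound 4 is estimated at 3 ug/mL, between 0.8 ug/mL and 12 ug/mL, which would mean an expected step of a 3.3-fold lower number from compound 3 to compound 4 (0.52 log units; beyond the scatter).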

Compound 4, half-maximal inhibitory concentration: 0.334 ug/mL
Beside the measured number, compound 4's estimate is 9.0-fold (0.95 log units) above it; measured number outside the range, below it.
By their numbers in this assay, from the lowest: compound 4; then compound 1; then compound 3.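

This position on the aromatic ring, para to a large group, can move the number a long way in both directions: in this assay, aminomethyl in place of carboxy gives a 30-fold lower number from compound 3 to compound 4 (1.48 log units; beyond the scatter) and more than recovers what the carboxy group lost. Aminomethyl in place of hydroxy gives a 2.5-fold lower number from compound 1 to compound 4 (0.40 log units; beyond the scatter), a modest step but beyond the scatter, so hydroxy is not the best group here and compound 4 is the strongest of the three compounds with numbers. Nothing at hand explains why these groups differ.

Compound 2 has no number, so the steps to and from it cannot be read and the methyl ester remains unplaced. On these data alone, whether the nitrogen of aminomethyl matters remains open; hydroxymethyl, with oxygen in its place, or a longer chain such as aminoethyl would help to tell.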